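A few compounds are considered here, and "the series" means these few. Any claim that something is new, unique, unknown or untested is made for them only; others in the source may bear on it.

Measured so far in a functional assay on the whole organism (strain albino) for inhibition, with Rattus norvegicus as the target, read by paw edema, with stated times of 30 min and 5 h, at a dose of 0.28 mmol/kg by the oral route; a higher number here means more inhibition at the dose given (going by the name of the read-out), a lower number less inhibition:
compound 1 `C=CCn1c(SCC(=O)Nc2ccc(/C(C)=N/O)cc2)nnc1-c1ccccc1` gives 71%;
compound 2 `C/C(=N\O)c1ccc(NC(=O)CSc2nnc(-c3ccccc3)n2-c2ccccc2)cc1` gives 66%;
compound 3 `COc1ccc(-c2nnc(SCC(=O)Nc3ccc(/C(C)=N/O)cc3)n2-c2ccccc2)cc1OC` gives 76%.

Compound 3 has the highest of these three numbers, yet its gap to compound 1 and its gap to compound 2 both lie within the scatter, so the three cannot be ranked. Compound 4 `C=CCn1c(SCC(=O)Nc2ccc(/C(C)=N/O)cc2)nnc1-c1ccc(OC)c(OC)c1` differs from compound 3 in one place: allyl in place of phenyl on an aromatic nitrogen. Among the compounds with values here, the only measured step that bears on this change is its reverse, a number 5 percentage points lower from compound 1 to compound 2 (within the scatter). Turning that change around points to a small rise at most, again within the scatter, in this assay. The expected step is therefore a number 4 percentage points higher from compound 3 to compound 4 (within the scatter). Compound 4 is expected to give 80%, with a range from 68% to 91%.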

Compound 4, a percentage reported as inhibition, in the whole organism at one dose (the size of the read-out at that dose, not a potency): 79%
Beside the measured number, compound 4's estimate is 1 percentage points above it, and the stated range covers the measured number.
By their numbers in this assay, from the lowest: compounds 2, 1, 3 and 4 (each within the scatter of the next, the first and the last beyond it).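

In this assay, allyl in place of phenyl on the aromatic nitrogen now has a second reading, a number 3 percentage points higher from compound 3 to compound 4 (within the scatter), and it agrees with the first: the same change on two cores in this assay, a number 5 percentage points lower (within the scatter) from compound 1 to compound 2 and a number 3 percentage points lower (within the scatter) from compound 4 to compound 3, 2 percentage points apart, within the scatter of two such steps. The change to 3,4-dimethoxyphenyl also has a second reading, a number 8 percentage points higher from compound 1 to compound 4 (within the scatter), and it agrees with the first as well: the same change on two cores in this assay, a number 10 percentage points higher (within the scatter) from compound 2 to compound 3 and a number 8 percentage points higher (within the scatter) from compound 1 to compound 4, 2 percentage points apart, within the scatter of two such steps. Neither change therefore shows any difference between the two cores, though each step stays within the scatter.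

Still open, on these data alone, is whether a longer chain or an amine on that nitrogen would move the number beyond the scatter. The same question stands for a carboxylic acid-bearing phenyl in place of 3,4-dimethoxyphenyl.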